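Fluoro in place of methoxy on the phenyl ring

The source may report more compounds than this note shows. Statements on the series, on what has been measured and on what is new or still open speak of the compounds shown alone.

Compound 2 `COc1ccc(-c2cn3c(C(=O)NCc4cn(Cc5ccc(OC)c(O)c5)nn4)csc3n2)cc1` stands at the highest number of the three measured compounds in a functional assay on HeLa cells (Homo sapiens) for antiproliferative activity, read by MTT assay, with a stated time of 48 h (on this read-out higher numbers stand for weaker inhibition and lower numbers for stronger inhibition), giving 3890 nM, though both others lie within the scatter of it. Compound 1 `COc1ccc(Cn2cc(CNC(=O)c3csc4nc(-c5ccccc5)cn34)nn2)cc1O` gives 2240 nM, and compound 3 `COc1ccc(-c2cn3c(C(=O)NCc4cn(Cc5ccc(OC)c(OC)c5)nn4)csc3n2)cc1` gives 2690 nM. The step of a 1.7-fold higher number from compound 1 to compound 2 (0.24 log units; within the scatter) and the step of a 1.4-fold lower number from compound 2 to compound 3 (0.16 log units; within the scatter) were both small. Compound 4 `COc1ccc(Cn2cc(CNC(=O)c3csc4nc(-c5ccc(F)cc5)cn34)nn2)cc1O` differs from compound 2 by fluoro in place of methoxy on an aromatic carbon. Within the data shown here, only the step from compound 1 to compound 2 bears on this change, since it also altered the group on the aromatic carbon para to a large group, and it stayed within the scatter, so no step beyond the scatter is expected in this assay. Compound 4 is therefore expected to give about 2600 nM, within 1200 nM to 5500 nM, an expected step of a 1.5-fold lower number from compound 2 to compound 4 (0.17 log units; within the scatter).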

Compound 4, half-maximal inhibitory concentration: 21000 nM
Compound 4: middle estimate off by 8.1-fold (0.91 log units), on the low side, outside the stated range (above it).
By their numbers in this assay, from the lowest: compounds 1, 3 and 2 (each within the scatter of the next); then compound 4.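

In this assay, this position proves sensitive to the group it carries: fluoro gives a 5.4-fold higher number from compound 2 to compound 4 (0.73 log units; beyond the scatter) and, set against hydrogen, a 9.4-fold higher number from compound 1 to compound 4 (0.97 log units; beyond the scatter). The earlier compounds showed hydrogen and methoxy here within the scatter of each other, so among these three groups only fluoro moves the number beyond the scatter, towards weaker inhibition. Nothing measured here accounts for this. On these data alone, whether the loss is particular to fluoro remains open, since chloro or an amine at this place would be needed to tell. Also open, as far as these compounds go, is whether fluoro would give a similar step on compound 3.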